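The source may hold more compounds than are shown below. What is called first, only, known or untested is meant among the compounds shown, and "the series" means these compounds.

Working notes on the series.

Compound 1 `CCOC(=O)C1(C(=O)NCc2ccc(C)cc2)CC1c1cc(OC)c(OC)c(OC)c1` has more than one entry in a functional assay on QGY cells (Homo sapiens) for cytotoxicity, read by MTT assay, with a stated time of 48 h; on this read-out higher numbers stand for weaker inhibition and lower numbers for stronger inhibition. In this assay compound 1 gives > 100000 nM; 37900 nM (2 entries), and because the several entries the several entries of compound 1 in this assay, > 100000 nM; 37900 nM (2 entries) do not agree closely they are taken together with caution. Among the compounds with values here, compound 2 `CCOC(=O)[C@]1(C(=O)NCc2ccc(C)cc2)C[C@H]1c1cc(OC)c(OC)c(OC)c1` is drawn with defined configuration at both stereocentres, whereas compound 1 is drawn without (the fact that one of compounds 1 and 2 is drawn with a defined configuration and the other without, at the place where they differ); in this assay compound 2 gives 32100 nM, the only number it has here, with one further entry that carries no single number. Between compound 1 and compound 2 no step is given, and the two values shown lie within the usual scatter of each other.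

Compound 3 `CCOC(=O)[C@@]1(C(=O)NCc2ccc(C)cc2)C[C@@H]1c1cc(OC)c(OC)c(OC)c1` is the mirror image of compound 2: the two compounds have the same atoms and bonds and differ only in configuration as drawn: 2 of 2 stereo elements differ (all stereocentres are inverted: mirror images); a stereocentre at a saturated ring carbon is drawn R in compound 2 and S in compound 3; a stereocentre at a saturated ring carbon is drawn S in compound 2 and R in compound 3. Within the data shown here, no step between measured compounds is available for this change. Given the result of compound 1, which mixes both configurations, and the single number of compound 2, the step from compound 2 to compound 3 is expected to be small or to go toward weaker inhibition, with a real chance of a limit. Compound 3 is estimated at 55000 nM, within 15000 nM to 200000 nM, a step of a 1.7-fold higher number from compound 2 to compound 3 (0.23 log units; within the scatter) expected in this assay.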

Compound 3, half-maximal inhibitory concentration: > 100000 nM
Compound 3: a limit, no number; the forecaster's own chance of this, stated with the estimate: 35%; at least 1.8-fold (0.25 log units) between middle value and limit.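

Within the data shown here, the mirror-image pair gives the first step that can be read in this assay, and it lies beyond the scatter: an at least 3.1-fold higher number from compound 2 to compound 3 (0.49 log units; beyond the scatter). In this assay compound 3 gives > 100000 nM, which is a limit and not a number. With atoms and bonds unchanged, the earlier entries, which left compound 1 and compound 2 within the usual scatter of each other, gave no sign of a separation, whereas this pair ties the weaker read-out of compound 3 to the inversion of the two stereocentres on the ring carbons: the fact that compounds 2 and 3 differ only in the configuration as drawn

Among these compounds, how far compound 3 lies past its limit stays open, so the true size of the step is unknown, and the single number of compound 2 still sits beside an entry that carries no single number. Also open is whether the same separation between mirror images would persist with a carboxylic acid or an amine in place of the ester on the shared core, since every compound shown carries the same groups.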